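The source may report more compounds than this note shows. Statements on the series, on what has been measured and on what is new or still open speak of the compounds shown alone.

Three related compounds have so far been tested in a functional assay on RAW264.7 cells (Mus musculus) for inhibition, read by Griess assay, with stated times of 2 h and 18 h (on this read-out lower numbers stand for stronger inhibition and higher numbers for weaker inhibition), and none has given a number. Compound 1 `C[C@@H]1C(=O)C(O)=C2C(C)(C)C(=O)CC[C@]2(C)[C@@]1(O)CCc1ccoc1` returns > 50000 nM, which is a limit of the assay. Compound 2 `CC1=C(CCc2ccoc2)[C@@]2(C)CC[C@@H](O)C(C)(C)[C@@H]2[C@H](O)C1=O` returns > 50000 nM, also a limit. Compound 3 `CC(=O)O[C@@H]1CC[C@@]2(C)[C@@H](C(=O)[C@H](O)[C@@H](C)[C@]2(O)CCc2ccoc2)C1(C)C` returns > 50000 nM, again a limit. The three therefore stand together, as the limit of > 50000 nM in this assay, at which 3 of the 3 values shown sit, and the data cannot place them in any order. Compound 2 has no measured potency of its own from which to count a step.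

Compound 4 `CC1=C(CCc2ccoc2)[C@@]2(C)CCCC(C)(C)[C@@H]2[C@H](O)C1=O` is the next to be read, and it departs from compound 2 in one place: hydrogen in place of hydroxy on a saturated ring carbon. This puts hydrogen in place of hydroxy on a saturated ring carbon, next to the ring atom that bears two methyl groups. No measured pair among these compounds shows what such a change does in this assay. Within the data shown here, the only guide is that compound 2 gives > 50000 nM, a limit shared by the other two compounds. On that basis no step beyond the scatter is expected, in either direction, and the expected step is a number no higher from compound 2 to compound 4 (the limit leaves the size open). In this assay the estimate for compound 4 is 50000 nM, with an expected range of 20000 nM to 100000 nM.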

Compound 4, half-maximal inhibitory concentration: > 50000 nM
Compound 4 gave a limit, no number; the forecaster's own chance of this, stated with the estimate: 65%; the middle value lies on the limit itself.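

In this assay compound 4 returns > 50000 nM, which is a limit and not a number. Compound 2 also stands at a limit, so no step can be read between compound 2 and compound 4. The compounds shown leave open what hydrogen in place of hydroxy does to potency, and how far any of them inhibits in this assay.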